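Acrylamide series: aryl swap at the fused core

The compounds below may be only part of what the source reports. "The series", "measured", "known", "first", "only" and "open" are said of these compounds alone.

Compound 1 `COc1ccc(-c2nn3cc(-c4cccc(N)c4)nc3s2)cc1OC` and compound 3 `Nc1cccc(-c2cn3nc(-c4ccccc4)sc3n2)c1` carry a free amine on the pendant ring. Among the measured compounds shown here, in a functional assay on FM3A cells (Mus musculus) for inhibition, read by cell counting, with a stated time of 2 days (a lower number here means a stronger inhibitor, a higher number a weaker inhibitor), compound 1 gives 13000 nM and compound 3 gives 14000 nM; no computed step joins them, and the two values sit close together. For the measured compounds named here, compound 2 `C=C(Br)C(=O)Nc1cccc(-c2cn3nc(-c4ccc(OC)c(OC)c4)sc3n2)c1` replaces the amine hydrogen with a (1-bromoethenyl)carbonyl group, and the step of a 120-fold lower number from compound 1 to compound 2 (2.07 log units; beyond the scatter) is the only measured step in the set. Compound 2 gives 110 nM and stands lowest of the three numbers, with compound 1 and compound 3 both well beyond the scatter above it.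

Compound 4 `C=C(Br)C(=O)Nc1cccc(-c2cn3nc(-c4ccc(CC)cc4)sc3n2)c1` keeps the acylated amine of compound 2 and changes the other aryl group: 4-ethylphenyl in place of 3,4-dimethoxyphenyl on an aromatic carbon. Going by the values given here, the one measured step concerns the nitrogen acylation, not this position, so it does not bear directly on the change. Among the compounds with values here, the only information on the aryl group is the pair compound 1 and compound 3, whose values lie within the scatter of each other although their aryl groups differ. On that basis the step of a 1.4-fold higher number from compound 2 to compound 4 (0.13 log units; within the scatter) is expected to be small, without a clear direction. Compound 4 is therefore estimated at 150 nM, with a range from 50 nM to 500 nM.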

Compound 4, half-maximal inhibitory concentration: 3300 nM
For compound 4 the middle estimate is 22-fold (1.34 log units) below the measured one; the measured number lies above the stated range.
By their numbers in this assay, from the lowest: compound 2; then compound 4; then compounds 1 and 3 (each within the scatter of the next).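

In this assay, the aryl group on the aromatic carbon next to the ring sulfur proves to be a sensitive position once the amine carries the (1-bromoethenyl)carbonyl group, with a 30-fold higher number from compound 2 to compound 4 (1.48 log units; beyond the scatter). The free-amine pair gave no sign of this, with compound 1 at 13000 nM and compound 3 at 14000 nM, but that pair involves a different aryl change, so its close values do not carry over to the acylated amides. Nothing measured here accounts for the size of the step.

On these data alone, the swap removes both methoxy groups and adds the ethyl group in one change, so it remains open whether the step follows from losing 3,4-dimethoxyphenyl or from introducing 4-ethylphenyl, a question that a 4-methoxyphenyl or plain phenyl analogue bearing the same amide would help to separate. Also open, as far as these compounds go, is whether the step depends on the acylated amine, which a free-amine compound carrying 4-ethylphenyl would test.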